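The compounds below may be only part of what the source reports. "The series", "measured", "known", "first", "only" and "open" are said of these compounds alone.

Measured so far in an ADME assay on L929 cells (Mus musculus) for cytotoxicity, read by resazurin assay, with a stated time of 96 h; a higher number here means that more compound is tolerated, a lower number that less compound is tolerated

compound 1 `CNC(=S)N/N=C(/COc1ccc(Br)cc1)c1ccc(OC)cc1` gives "not determined" (no result reported)
compound 2 `NC(=S)N/N=C(\COc1ccccc1)c1ccc(Br)cc1` gives 54900 nM

Among the compounds with values here, compound 2 holds the only number, so it cannot yet be ranked against anything, and compound 1 offers no comparison. Compound 3 `COc1ccc(OC/C(=N\NC(N)=S)c2ccc(Br)cc2)cc1` differs from compound 2 by methoxy in place of hydrogen on an aromatic carbon on the ring that carries the ether oxygen, where a methoxy stands in place of hydrogen para to a large group. Within the data shown here, no step between measured compounds exists to size this change in this assay and the data give no firm direction. The expectation therefore rests on compound 2 at 54900 nM alone, with no shift beyond the usual scatter foreseen. The expected step is a 1.2-fold lower number from compound 2 to compound 3 (0.09 log units; within the scatter) and a slight lean towards less compound tolerated is assumed. For compound 3 the estimated value is 45000 nM with an expected range from 15000 nM to 130000 nM in this read-out.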

Compound 3, half-maximal cytotoxic concentration: 102000 nM
The estimate for compound 3 lay 2.3-fold (0.36 log units) below the measured number; low and high end bracket the measured number.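

In this assay, methoxy in place of hydrogen on an aromatic carbon, para to a large group, gives a 1.9-fold higher number from compound 2 to compound 3 (0.27 log units; within the scatter), and this first readable step in the series does not separate the two compounds. At this position on the ring that carries the ether oxygen, the change therefore leaves the tolerated concentration within the usual scatter, which is all that a single pair can show. No supporting measurement bears on this result.

Going by these compounds, whether an amine, a carboxylic acid or a longer alkoxy chain at this position would move the number beyond the scatter remains open. Also open, on these data alone, is whether methoxy would give a similar step at another place on the shared core, and compound 1, with "not determined" (no result reported), adds no comparison.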